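The source may report more compounds than this note shows. Statements on the series, on what has been measured and on what is new or still open speak of the compounds shown alone.

Of the compounds shown here, two have been measured so far in a functional assay on HEK293 cells for antagonist activity at proteinase-activated receptor 4 (Homo sapiens), read by FLIPR and calcium flux, with a stated time of 30 min; a lower number here means a stronger inhibitor, a higher number a weaker inhibitor. Compound 1 `CCOc1nn2cc(-c3cc4ccccc4o3)nc2s1` gives 67 nM. Compound 2 `COc1cc(OCc2cccc(COc3ccccc3)c2)c2cc(-c3cn4nc(OC)sc4n3)oc2c1` gives 3.2 nM, the lowest of the two numbers and far below compound 1. Compound 3 `COc1cc(OCc2cccc(Oc3ccccc3)c2)c2cc(-c3cn4nc(OC)sc4n3)oc2c1` has not yet been measured; it differs from compound 2 by phenoxy in place of phenoxymethyl on an aromatic carbon. Within the data shown here, no measured pair shows what this kind of change does, so there is nothing to anchor the step. Compound 3 is expected to show only a small step, a 1.6-fold higher number from compound 2 to compound 3 (0.19 log units; within the scatter), possibly within the scatter. Compound 3 is estimated to give 5 nM, with a range from 1.5 nM to 16 nM.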

Compound 3, half-maximal inhibitory concentration: 1.2 nM
Compound 3: the middle estimate sits 4.2-fold (0.62 log units) above what was measured, outside the stated range (below it).
By their numbers in this assay, from the lowest: compound 3; then compound 2; then compound 1.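

Phenoxy in place of phenoxymethyl on this aromatic carbon gives a 2.7-fold lower number from compound 2 to compound 3 (0.43 log units; beyond the scatter) in this assay. This first measured pair at the position shows that the smaller of these two groups is tolerated here, and that the inhibitor even becomes modestly stronger. Nothing available explains this gain. As far as these compounds go, whether the change would give the same result with any other core remains open. At this position, only phenoxy and phenoxymethyl can be compared so far, leaving open how a benzyloxy group or an anilino group would behave.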